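This account rests on a few compounds, and the source may have more. Where it says the series, first, only, none or still open, it means among the compounds named here.

Three compounds share one core and differ only in the aromatic group attached to the five-membered ring. Compound 3 `Cc1ccccc1-c1sc(N)c(C(=O)c2ccc(Cl)cc2)c1CC(C)(C)C` is the starting point here; in an assay on CHO cells for displacement of a labelled ligand from adenosine receptor A1 (Homo sapiens), read by scintillation counting, tested at 10 uM (on this read-out lower numbers stand for less inhibition and higher numbers for more inhibition at the one concentration tested (going by the name of the read-out)), compound 3 gives 1%. Its two measured companions sit at the same level: compound 1 `CC(C)(C)Cc1c(-c2ccc(Cl)c(Cl)c2)sc(N)c1C(=O)c1ccc(Cl)cc1` gives 1%, and compound 2 `COCCOc1ccc(-c2sc(N)c(C(=O)c3ccc(Cl)cc3)c2CC(C)(C)C)cc1` gives 1%. Going by the values given here, the single step with one change, no change at the digits printed from compound 1 to compound 3 (within the scatter), exchanged a 3,4-dichlorophenyl group for a 2-methylphenyl group on an aromatic carbon and moved nothing beyond the scatter. So on the numbers shown, compound 3 is level with compounds 1 and 2, and none of the three shows appreciable inhibition.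

Compound 4 `COc1ccc(-c2sc(N)c(C(=O)c3ccc(Cl)cc3)c2CC(C)(C)C)cc1` has not yet been measured. Compared with compound 3, (4-methoxyphenyl in place of 2-methylphenyl on an aromatic carbon). The change sits next to the ring sulfur and next to the ring atom that bears a neopentyl group. Among the compounds with values here, the one measured step bearing on it, from compound 1 to compound 3, was flat, and compound 2, which carries a different oxygen-bearing aromatic group, is likewise flat. No change beyond the scatter is therefore expected in this assay: the expected step is a number 1 percentage points higher from compound 3 to compound 4 (within the scatter). Compound 4 is estimated at 2%, with a range from -5% to 12%.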

Compound 4, a percentage reported as inhibition, at one concentration (the size of the read-out at that concentration, not a potency): 1%
Compound 4: middle estimate off by 1 percentage points, on the high side; measured number inside the range.
By their numbers in this assay, from the lowest: compounds 1, 2, 3 and 4 (each within the scatter of the next).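

Compound 4 puts a 4-methoxyphenyl group on the aromatic carbon next to the ring sulfur, and in this assay exchanging the 2-methylphenyl group for it gives no change at the digits printed from compound 3 to compound 4 (within the scatter) and so adds a single hydrogen-bond acceptor to the entering group without moving the read-out. Two further comparisons now link all the compounds at this position: cutting the longer oxygen-bearing chain back to a methoxy group gives no change at the digits printed from compound 2 to compound 4 (within the scatter) and swapping the 3,4-dichlorophenyl group for the 4-methoxyphenyl group gives no change at the digits printed from compound 1 to compound 4 (within the scatter) so that chlorine atoms, a methyl group and both oxygen-bearing chains all leave the number in the same place. Nothing available here explains this flat result.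

On these data alone, all four compounds carry a substituted phenyl ring at this position, so it remains open whether a ring bearing an amine or a carboxylic acid, or a saturated chain in place of the ring, would give any inhibition at all. The neopentyl, amino and (4-chlorophenyl)carbonyl groups are the same throughout, which leaves open whether changing any of them would lift the compounds off this low level.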